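Phenyl for ethyl on the saturated ring carbon

The compounds below may be only part of what the source reports. "The series", "measured", "known", "first", "only" and "open" are said of these compounds alone.

Measured compounds:
compound 1 `N#C/N=C1\N(CCCCCOc2ccc(Cl)cc2)C(=O)CN1c1ccncc1` gives 4200 nM
compound 2 `CCC1C(=O)N(CCCCCOc2ccc(Cl)cc2)/C(=N\C#N)N1c1ccncc1` gives 4320 nM

Both compounds were tested in a functional assay on HepG2 cells (Homo sapiens) for cytotoxicity (a lower number here means a stronger inhibitor, a higher number a weaker inhibitor), where compound 2 stands with the higher of the two numbers, but its step from compound 1 is within the scatter: a 1.0-fold higher number from compound 1 to compound 2 (0.01 log units; within the scatter). Compound 3 `N#C/N=C1\N(CCCCCOc2ccc(Cl)cc2)C(=O)C(c2ccccc2)N1c1ccncc1` has not been measured yet. It differs from compound 2 in one place: phenyl in place of ethyl on a saturated ring carbon. Going by the values given here, the only step on record that touches this position, from compound 1 to compound 2, swapped hydrogen for ethyl and stayed within the scatter. A phenyl is a larger replacement, so the record gives no firm direction; a step of no more than the scatter in either direction is the most defensible expectation for a 1.0-fold higher number from compound 2 to compound 3 (0.02 log units; within the scatter). Compound 3 is therefore expected to land near 4500 nM, with a range from 1500 nM to 13000 nM.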

Compound 3, half-maximal inhibitory concentration: 415 nM
Estimate against measurement, compound 3: 11-fold (1.04 log units) above; the whole stated range lies above it.
By their numbers in this assay, from the lowest: compound 3; then compounds 1 and 2 (each within the scatter of the next).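

In this assay, the saturated ring carbon proves sensitive to what it carries: phenyl in place of ethyl gives a 10-fold lower number from compound 2 to compound 3 (1.02 log units; beyond the scatter), and phenyl in place of hydrogen gives a 10-fold lower number from compound 1 to compound 3 (1.01 log units; beyond the scatter). Hydrogen and ethyl alone, with a 1.0-fold higher number from compound 1 to compound 2 (0.01 log units; within the scatter), had made this position look silent, so among these three compounds only phenyl, the one group with an aromatic ring, shifts the number beyond the scatter, while the ethyl of compound 2 does not. Nothing available explains why phenyl has this effect.

The compounds shown leave open whether a cyclohexyl, benzyl or pyridyl group on the same carbon would behave like phenyl or like ethyl. Also open, on these data alone, is whether a chlorine or methoxy group on the phenyl ring would move the number further.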